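Urea series: cyclohexyl in place of 4-methylphenyl

The compounds below may be only part of what the source reports. "The series", "measured", "known", "first", "only" and "open" are said of these compounds alone.

Working notes on a small set of urea-type compounds tested in a functional assay on MDA-MB-231 cells (Homo sapiens) for cytotoxicity, read by MTT assay, with a stated time of 48 h; a lower number here means a stronger inhibitor, a higher number a weaker inhibitor. Compound 1 `COc1ccc(CN(C(=O)Nc2ccc(F)c(Cl)c2)n2cnnc2)cc1OC` gives 27900 nM in this assay. Compound 2 `COc1ccc(OC)c(CN(C(=O)Nc2ccc(C)cc2)n2cnnc2)c1` gives > 50000 nM in this assay, which is a limit of the assay and not a number. Compound 2 therefore stands at the weak end of what has been measured so far, and the evidence for this is the limit of > 50000 nM in this assay, at which 1 of the 2 values shown sits. Compounds 1 and 2 differ in more than one place, so their two values are only set side by side here without a step between them.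

Compound 3 `COc1ccc(OC)c(CN(C(=O)NC2CCCCC2)n2cnnc2)c1` has not been measured. It differs from compound 2 by cyclohexyl in place of 4-methylphenyl on an amide-type nitrogen. No measured step covers a change of this kind in the set. The step from compound 2 to compound 3 is expected to be a step that the limit leaves unreadable from compound 2 to compound 3, which is no change beyond the scatter. Compound 3 is thus estimated at 60000 nM, with a range from 20000 nM to 200000 nM, and a limit is considered the more likely outcome.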

Compound 3, half-maximal inhibitory concentration: > 50000 nM
Compound 3: only a limit was reported (the forecaster's own chance of this, stated with the estimate: 65%); the middle value lies beyond the limit too.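

For the compounds shown here, compound 2 and compound 3 both end at a limit of the assay and not at a number, so no step between them can be read: the limit of > 50000 nM in this assay, at which 2 of the 3 values shown sit. The compounds shown leave open whether cyclohexyl in place of 4-methylphenyl on an amide-type nitrogen changes the read-out in either direction.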